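Methyl added to compound 2: expected effect on growth inhibition

This account rests on a few compounds, and the source may have more. Where it says the series, first, only, none or still open, it means among the compounds named here.

Measured in a functional assay on LoVo cells (Homo sapiens) for inhibition, read by colorimetric assay and MTT assay, with a stated time of 72 h; a higher number here means a weaker inhibitor, a lower number a stronger inhibitor
- compound 1 `Cn1c2cnc1OCCCCCCCCCCOc1cc3ccccc3cc1-2` gives 28000 nM
- compound 2 `C=CCCCCOc1ccccc1-c1cnc(OCCC=C)n1C` gives 12000 nM
- compound 3 `COc1ccc(C)cc1-c1cnc(OCCCCc2ccccc2)n1C` gives 27000 nM

Compound 2 stands lowest of the three, and both compound 1 and compound 3 lie above it by more than the scatter. Compound 4 `C=CCCCCOc1ccc(C)cc1-c1cnc(OCCC=C)n1C` is compound 2 with methyl in place of hydrogen on an aromatic carbon. Within the data shown here, no measured pair isolates this change, so the expectation rests on its small size alone: no shift beyond the scatter is expected in this assay for this step. The estimated step (a 1.2-fold higher number from compound 2 to compound 4 (0.07 log units; within the scatter)) is therefore small. For compound 4 the expected value is 14000 nM with 7000 nM to 27000 nM as the estimated range.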

Compound 4, half-maximal inhibitory concentration: 41000 nM
Compound 4: middle estimate off by 2.9-fold (0.47 log units), on the low side; measured number above the stated range.
By their numbers in this assay, from the lowest: compound 2; then compounds 3, 1 and 4 (each within the scatter of the next).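

In this assay, one methyl in place of hydrogen, on the aromatic carbon para to a (hex-5-en-1-yl)oxy group and meta to a large group, gives a 3.4-fold higher number from compound 2 to compound 4 (0.53 log units; beyond the scatter). Among these compounds, this is the first one-place comparison, and it shows that this position is not indifferent to a single added carbon: inhibition weakens. Nothing at hand bears on the cause of this step. On these data alone, whether the loss is specific to methyl remains open, as a fluorine, methoxy or hydroxyl on the same carbon would show. Also open, as far as these compounds go, is whether the step persists with a longer chain in place of the (hex-5-en-1-yl)oxy group.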